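Shifting a trifluoromethoxy group: what to expect of compound 3

This account rests on a few compounds, and the source may have more. Where it says the series, first, only, none or still open, it means among the compounds named here.

Compound 1 `CC(O)(CS(=O)(=O)c1ccc(F)cc1)C(=O)Nc1ccc(S(F)(F)(F)(F)F)cc1`: 27700 nM
Compound 2 `CC(O)(CS(=O)(=O)c1ccc(OC(F)(F)F)cc1)C(=O)Nc1ccc(S(F)(F)(F)(F)F)cc1`: 39300 nM

In a functional assay on DU-145 cells (Homo sapiens) for antiproliferative activity, read by propidium iodide staining, with a stated time of 96 h (on this read-out lower numbers stand for stronger inhibition and higher numbers for weaker inhibition), compound 2 gives 39300 nM. Among the compounds with values here, this lies within the usual scatter of compound 1, the only other compound measured, so the two cannot be ranked against each other.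

Compound 3 `CC(O)(CS(=O)(=O)c1cccc(OC(F)(F)F)c1)C(=O)Nc1ccc(S(F)(F)(F)(F)F)cc1` has not yet been measured. It holds the same atoms as compound 2, joined differently: 3-(trifluoromethoxy)phenyl in place of 4-(trifluoromethoxy)phenyl on a sulfonyl sulfur. In words, 3-(trifluoromethoxy)phenyl stands in place of 4-(trifluoromethoxy)phenyl on a sulfonyl sulfur.

Within the data shown here, only one measured step bears on this, and only indirectly: a 1.4-fold higher number from compound 1 to compound 2 (0.15 log units; within the scatter). That step put trifluoromethoxy in place of fluoro on an aromatic carbon, which is a different kind of change. Among the measured compounds shown here, no measured pair shows what relocating this group does, so the expectation stays loose, and no step beyond the scatter is expected in this assay in either direction.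

The expected step is a 1.1-fold lower number from compound 2 to compound 3 (0.05 log units; within the scatter). For compound 3 the estimated value is 35000 nM, with an expected range from 17000 nM to 70000 nM.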

Compound 3, half-maximal inhibitory concentration: 26500 nM
Estimate against measurement, compound 3: 1.3-fold (0.12 log units) above; measured number inside the range.
By their numbers in this assay, from the lowest: compounds 3, 1 and 2 (each within the scatter of the next).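

In this assay, within the data shown here, moving the trifluoromethoxy group, with 3-(trifluoromethoxy)phenyl in place of 4-(trifluoromethoxy)phenyl on the sulfonyl sulfur, gives a 1.5-fold lower number from compound 2 to compound 3 (0.17 log units; within the scatter), so this is the first direct look at relocating the group, and the shift cannot be told apart from repeat-measurement noise. Putting 3-(trifluoromethoxy)phenyl in place of 4-fluorophenyl at that same sulfonyl sulfur gives a 1.0-fold lower number from compound 1 to compound 3 (0.02 log units; within the scatter), so taken with the earlier step, neither changing the group nor relocating it separates any of the three compounds, and they cannot be ranked against one another. No supporting data are available that could explain why these numbers stay so close together.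

The compounds shown carry only fluoro and trifluoromethoxy on this aromatic ring, so it remains open whether a quite different group there, such as an amine or a carboxylic acid, would produce a step beyond the scatter. From the compounds shown here alone, it is also open whether changes elsewhere on the shared core, rather than on this ring, would have any larger effect on the number in this assay.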